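A few compounds are considered here, and "the series" means these few. Any claim that something is new, unique, unknown or untested is made for them only; others in the source may bear on it.

Compound 2 `COc1ccc(S(=O)(=O)N2CC(C(=O)NC3CCN(C)CC3)c3ccccc32)c2ccccc12` is the reference point here. In a functional assay on CHO cells for antagonist activity at 5-hydroxytryptamine receptor 6 (Homo sapiens), read by FLIPR (on this read-out lower numbers stand for stronger inhibition and higher numbers for weaker inhibition), compound 2 gives 25.1 nM, the second highest of the three numbers recorded. Compound 1 `COc1ccc(S(=O)(=O)N2CC(C(=O)N(C)C3CCN(C)CC3)c3ccccc32)c2ccccc12` carries a methyl on the amide nitrogen, and in this assay compound 1 gives 7.94 nM; the step of a 3.2-fold higher number from compound 1 to compound 2 (0.50 log units; beyond the scatter) is modest but beyond the scatter. Compound 3 `COc1ccc(S(=O)(=O)N2CC(C(=O)NC3CCN(Cc4ccccc4)CC3)c3ccccc32)c2ccccc12` carries a phenyl on the saturated chain carbon bound to the ring amine nitrogen, and in this assay compound 3 gives 50.1 nM; the step of a 2.0-fold higher number from compound 2 to compound 3 (0.30 log units; within the scatter) stays within the scatter.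

Compound 4 `COc1ccc(S(=O)(=O)N2CC(C(=O)N3CC(N)C3)c3ccccc32)c2ccccc12` is not yet measured. The change from compound 2 is 3-aminoazetidin-1-yl in place of (1-methylpiperidin-4-yl)amino on a carbonyl carbon, a shift from a six-membered to a four-membered ring, while the amide nitrogen loses its hydrogen and becomes part of the ring itself. Both measured steps touch this region of the shared core: removing the methyl from the amide nitrogen cost a modest amount, and altering the ring amine hardly registered. The present change is larger than either, so the expected step is somewhat uncertain, with a mild weakening as the most likely outcome. Compound 4 is therefore estimated at 40 nM, within a range of 10 nM to 160 nM, corresponding to an expected step of a 1.6-fold higher number from compound 2 to compound 4 (0.20 log units; within the scatter).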

Compound 4, inhibition constant: 158 nM
For compound 4 the middle estimate is 4.0-fold (0.60 log units) below the measured one; the measured number falls inside the stated range.
By their numbers in this assay, from the lowest: compound 1; then compounds 2 and 3 (each within the scatter of the next); then compound 4.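

Exchanging the whole amine part on the carbonyl carbon reaches further than the earlier edits did: in this assay, 3-aminoazetidin-1-yl in place of (1-methylpiperidin-4-yl)amino gives a clear loss (a 6.3-fold higher number from compound 2 to compound 4 (0.80 log units; beyond the scatter)), whereas the change on the ring amine stayed within the scatter. Set against the N-methylated amide, the exchange gives the only step in this set rated large (a 20-fold higher number from compound 1 to compound 4 (1.30 log units; beyond the scatter)), so the group on this carbonyl carbon can shift the number well beyond what the amide methyl alone showed. No measurement here bears on why the number rises with this exchange.

The single exchange alters several things at once, namely the ring size, the place of the amide nitrogen within the ring and the amine on the ring, and the compounds shown do not separate these contributions. On these data alone, it remains open how a piperidin-1-yl carbonyl bearing a 4-amino group, a 3-aminopyrrolidin-1-yl group or a 3-(dimethylamino)azetidin-1-yl group would read on this carbonyl carbon, and each of these would help show which part of the exchange matters.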